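Replacing the anilide aryl of compound 1 with an indoline nitrogen

The compounds below may be only part of what the source reports. "The series", "measured", "known", "first", "only" and "open" are said of these compounds alone.

Compound 1 `Cc1ccc(C)c(NC(=O)CSc2nnc(-c3ccoc3C)n2Cc2ccco2)c1` — 398 nM
Compound 2 `Cc1occc1-c1nnc(SCC(=O)Nc2ccc(F)c(Cl)c2)n1Cc1ccco1` — 39.8 nM
Compound 3 `CC(=O)c1cccc(NC(=O)CSc2nnc(-c3ccoc3C)n2Cc2ccco2)c1` — 316 nM

In a functional assay on CHO cells for antagonist activity at Orexin receptor type 2 (Homo sapiens), read by FLIPR and calcium flux (on this read-out higher numbers stand for weaker inhibition and lower numbers for stronger inhibition), compound 1 gives the highest of the three numbers; compound 3 sits nearest, and compound 2 is furthest, as a 10-fold lower number from compound 1 to compound 2 (1.00 log units; beyond the scatter) and a 1.3-fold lower number from compound 1 to compound 3 (0.10 log units; within the scatter) show. Compound 4 `Cc1occc1-c1nnc(SCC(=O)NN2CCc3ccccc32)n1Cc1ccco1` differs from compound 1 by 2,3-dihydro-1H-indol-1-yl in place of 2,5-dimethylphenyl on an amide-type nitrogen. Neither measured step is a close match, since both swap one aryl for another; they only show that a change on this amide-type nitrogen can range from within the scatter to a modest step. Compound 4 is therefore expected to stay near compound 1, with a 1.3-fold higher number from compound 1 to compound 4 (0.10 log units; within the scatter) as the estimated step and a wide range. The estimate for compound 4 is 500 nM, between 120 nM and 2500 nM.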

Compound 4, inhibition constant: 1000 nM
Estimate against measurement, compound 4: 2.0-fold (0.30 log units) below, within the range that was stated.
By their numbers in this assay, from the lowest: compound 2; then compounds 3 and 1 (each within the scatter of the next); then compound 4.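

In this assay, 2,3-dihydro-1H-indol-1-yl on the amide-type nitrogen gives a 2.5-fold higher number from compound 1 to compound 4 (0.40 log units; beyond the scatter) and a 3.2-fold higher number from compound 3 to compound 4 (0.50 log units; beyond the scatter) and, against the best phenyl group shown, a 25-fold higher number from compound 2 to compound 4 (1.40 log units; beyond the scatter) in this series. Unlike the swaps among phenyl groups, one of which stayed within the scatter, this change lies beyond the scatter against all three, leaving compound 4 the weakest of the four. Nothing shown here explains this loss. The compounds shown leave open how a benzyl group or a piperidine ring would read on this nitrogen.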